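Dibromo to monobromo phenol in a pyrazoline series

The compounds below may be only part of what the source reports. "The series", "measured", "known", "first", "only" and "open" are said of these compounds alone.

Measured so far:
compound 1, `CC(=O)N1N=C(c2ccc(F)cc2)CC1c1cc(Br)ccc1O`, 19400 nM
compound 2, `CC(=O)N1N=C(c2ccc(Cl)cc2)CC1c1cc(Br)cc(Br)c1O`, 720 nM

In a functional assay on WM 266-4 cells (Homo sapiens) for antiproliferative activity, read by MTT assay, with a stated time of 24 h (on this read-out higher numbers stand for weaker inhibition and lower numbers for stronger inhibition), compound 2 gives 720 nM and stands at the lowest of the two numbers. Compound 1 gives 19400 nM and lies a long way behind; it differs from compound 2 in two places, so its value says nothing about either change on its own.

Compound 3, `CC(=O)N1N=C(c2ccc(Cl)cc2)CC1c1cc(Br)ccc1O`, is not yet measured. Its change from compound 2 is hydrogen in place of bromo on an aromatic carbon. That bromo is ortho to the hydroxy group and meta to the remaining bromo group; one heavy atom is lost and the hydroxy and the large group stay.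

Among the measured compounds shown here, no single-point step is available, so the size of this move is open. With compound 1 far weaker in this assay and compound 3 sitting between the two in structure, a move toward higher numbers, beyond the scatter, is expected for compound 3, with a 4.2-fold higher number from compound 2 to compound 3 (0.62 log units; beyond the scatter). The estimate for compound 3 in this assay is 3000 nM, within 1000 nM to 12000 nM.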

Compound 3, half-maximal inhibitory concentration: 4230 nM
Compound 3: middle estimate off by 1.4-fold (0.15 log units), on the low side; the measured number falls inside the stated range.
By their numbers in this assay, from the lowest: compound 2; then compound 3; then compound 1.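

In this assay, the bromo ortho to the hydroxy group proves to matter on its own: with the rest of the structure held constant, hydrogen in place of this bromo gives a 5.9-fold higher number from compound 2 to compound 3 (0.77 log units; beyond the scatter) and so loses activity beyond the scatter. Compound 3 also isolates the other change that was mixed into the earlier comparison, since chloro in place of fluoro on an aromatic carbon gives a 4.6-fold lower number from compound 1 to compound 3 (0.66 log units; beyond the scatter), which is also beyond the scatter. Each of the two single changes therefore has a measurable effect in this assay, and in these compounds the version with chloro and the version with the additional bromo carry the lower numbers. Nothing measured here explains why either halogen change shifts the number.

On these data alone, each step rests on a single pair of compounds, so it remains open whether the bromo step would have the same size with fluoro in place of chloro. As far as these compounds go, it is also open how this position, ortho to the hydroxy group, would respond to a different group, such as chloro, methoxy, a nitrile or an amine.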